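A few compounds are considered here, and "the series" means these few. Any claim that something is new, unique, unknown or untested is made for them only; others in the source may bear on it.

In a functional assay on WM-115 cells (Homo sapiens) for cytotoxicity, read by MTT assay, with a stated time of 46 h (a higher number here means a weaker inhibitor, a lower number a stronger inhibitor), compound 1 `O=C1/C(=C\c2ccc(Cl)cc2)C(c2ccccc2)Oc2ccccc21` gives 27400 nM and compound 2 `O=C1/C(=C/c2ccc(Br)cc2)C(c2ccccc2)Oc2ccccc21` gives 25900 nM, so these two values lie within the usual scatter of each other. Compound 3 `O=C1/C(=C\c2ccc(Br)cc2)C(c2ccccc2)Oc2ccccc21` is still unmeasured. Its difference from compound 2 is the two compounds have the same atoms and bonds; at least one stereo element is drawn with a configuration in one of them and without one in the other: 1 of 2 stereo elements differ; a double bond is drawn E in compound 2 and Z in compound 3: the same atoms and bonds, with a double bond drawn E in compound 2 and Z in compound 3. Among the measured compounds shown here, no measured step covers this change, so no shift beyond the scatter is expected in either direction. The expected change is a 1.0-fold higher number from compound 2 to compound 3 (0.00 log units; within the scatter). For compound 3 the estimate is 26000 nM, with an expected range of 12000 nM to 55000 nM.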

Compound 3, half-maximal inhibitory concentration: 32600 nM
The estimate for compound 3 lay 1.3-fold (0.10 log units) below the measured number; the measured number falls inside the stated range.
By their numbers in this assay, from the lowest: compounds 2, 1 and 3 (each within the scatter of the next).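

In this assay, the double-bond geometry and the halogen can now be read apart, which compounds 1 and 2, differing in both, did not allow. The E-to-Z change gives a 1.3-fold higher number from compound 2 to compound 3 (0.10 log units; within the scatter), and bromo in place of chloro gives a 1.2-fold higher number from compound 1 to compound 3 (0.08 log units; within the scatter), so neither change alone separates these compounds. The geometry step needs a caveat, as its reading rests on: the fact that one of compounds 2 and 3 is drawn with a defined configuration and the other without, at the place where they differ

Open, as far as these compounds go, is whether an amine or a carboxylic acid in place of the halogen would move the number beyond the scatter.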